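Swapping a Methoxy for a Nitro on Compound 3

The source may report more compounds than this note shows. Statements on the series, on what has been measured and on what is new or still open speak of the compounds shown alone.

Of the compounds shown here, three have so far been tested in a functional assay on HL-60 cells (Homo sapiens) for inhibition, read by CCK-8 assay, with a stated time of 48 h; a higher number here means a weaker inhibitor, a lower number a stronger inhibitor. Compound 1 `O=C(NCCNS(=O)(=O)c1ccc(-c2ccccc2OCc2ccccc2)s1)Nc1cc(Cl)cc(Cl)c1` gives 11700 nM in this assay. Compound 2 `O=[N+]([O-])c1ccc(Oc2ccccc2-c2ccc(S(=O)(=O)NCCNC(=S)Nc3cccc(Cl)c3)s2)cc1` returns no number in this assay, only (the limit of > 50000 nM in this assay, at which 1 of the 3 values shown sits). For compound 2 the result stands as > 50000 nM, which is a limit and not a measurement. Compound 3 `COc1ccc(NC(=S)NCCNS(=O)(=O)c2sccc2-c2ccc(C)cc2Oc2ccc(O)c(O)c2)cc1` gives 4100 nM in this assay, the lowest of the two numbers that exist here; compound 1 sits at a higher number, and that gap lies beyond the usual scatter of repeated measurements.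

Compound 4 `Cc1ccc(-c2ccsc2S(=O)(=O)NCCNC(=S)Nc2ccc([N+](=O)[O-])cc2)c(Oc2ccc(O)c(O)c2)c1` has not yet been measured. It differs from compound 3 in a single place: nitro in place of methoxy on an aromatic carbon. Going by the values given here, no two measured compounds differ from each other in only one place, so no measured step shows what this swap does in this assay, and the expectation below rests on compound 3 alone. The step is expected to be small, at most a modest move towards a weaker inhibitor: a 1.5-fold higher number from compound 3 to compound 4 (0.17 log units; within the scatter). Compound 4 is therefore estimated at 6000 nM, with a plausible range from 2000 nM to 25000 nM.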

Compound 4, half-maximal inhibitory concentration: 2900 nM
Beside the measured number, compound 4's estimate is 2.1-fold (0.32 log units) above it; low and high end bracket the measured number.
By their numbers in this assay, from the lowest: compounds 4 and 3 (each within the scatter of the next); then compound 1. At a limit, above all of these: compound 2.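

Going by these compounds alone, compound 3 and compound 4 give the first comparison in this set that changes only one place, and in this assay putting nitro in place of methoxy gives a small step (a 1.4-fold lower number from compound 3 to compound 4 (0.15 log units; within the scatter)). Within the data shown here, on this aromatic carbon, para to a large group, the assay therefore does not separate the two groups: going from 4-methoxyphenyl to 4-nitrophenyl leaves the number where it was, within the usual scatter, and the earlier compounds could not show this as they differ from one another in more than one place. Nothing available here bears on why these two groups read alike.

On these data alone, it remains open whether other groups on this carbon, such as an amine or a carboxylic acid, would also leave the number unmoved, or whether a plain hydrogen there would shift it beyond the scatter. As far as these compounds go, it is also open whether the same swap would read alike on a different core, as compound 1 and compound 2 differ from compound 3 in more than one place and cannot answer that.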